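The source may hold more compounds than are shown below. What is called first, only, known or untested is meant among the compounds shown, and "the series" means these compounds.

Measured in a functional assay on HepG2 cells (Homo sapiens) for inhibition, read by MTT assay, with a stated time of 120 h; on this read-out lower numbers stand for stronger inhibition and higher numbers for weaker inhibition:
Compound 1 `O=C(/C=C/c1ccc(NC(=O)Nc2ccc(Cl)c(C(F)(F)F)c2)cc1)NC1CCC1` gives 7510 nM.
Compound 2 `CC(NC(=O)c1cccc(-c2ccc(NC(=O)Nc3ccc(Cl)c(C(F)(F)F)c3)cc2)c1)c1ccccc1` gives 5670 nM.
Compound 3 `CNC(=O)/C=C/c1ccc(NC(=O)Nc2ccc(Cl)c(C(F)(F)F)c2)cc1` gives 20400 nM.

Compound 3 stands highest of the three in this assay, beyond the scatter above both compound 1 and compound 2. Compound 4 `CNC(=O)c1cccc(-c2ccc(NC(=O)Nc3ccc(Cl)c(C(F)(F)F)c3)cc2)c1` carries 3-(methylcarbamoyl)phenyl in place of 2-(methylcarbamoyl)ethenyl on an aromatic carbon. For the measured compounds named here, no measured step matches this change; the single measured step, a 2.7-fold higher number from compound 1 to compound 3 (0.43 log units; beyond the scatter), concerns the amide substituent and not the linker. Compound 2, which also carries a phenyl in that place but a different amide, gives a lower number than compound 3, yet the two differ in two places, so it is only a hint. The step from compound 3 to compound 4 is therefore expected to be a 1.9-fold lower number from compound 3 to compound 4 (0.27 log units; within the scatter), a modest decrease with wide uncertainty. Compound 4 is estimated at 11000 nM, between 4000 nM and 30000 nM.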

Compound 4, half-maximal inhibitory concentration: 37100 nM
The estimate for compound 4 lay 3.4-fold (0.53 log units) below the measured number; the measured number lies above the stated range.
By their numbers in this assay, from the lowest: compounds 2 and 1 (each within the scatter of the next); then compounds 3 and 4 (each within the scatter of the next).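

In this assay, 3-(methylcarbamoyl)phenyl in place of 2-(methylcarbamoyl)ethenyl gives a 1.8-fold higher number from compound 3 to compound 4 (0.26 log units; within the scatter) so with the methyl amide this exchange does not separate the two compounds. The amide substituent does separate them: methyl in place of 1-phenylethyl gives a 6.5-fold higher number from compound 2 to compound 4 (0.82 log units; beyond the scatter) and the exchange of the whole group carrying the cyclobutyl amide gives a 4.9-fold higher number from compound 1 to compound 4 (0.69 log units; beyond the scatter) in the same direction. Nothing available explains these numbers.
The compounds shown leave open how a carboxylic acid or an amine in place of the methylcarbamoyl group would read here, and whether a longer chain on the amide nitrogen would follow 1-phenylethyl.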